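This account rests on a few compounds, and the source may have more. Where it says the series, first, only, none or still open, it means among the compounds named here.

Measured compounds and their values in a functional assay on A375P cells (Homo sapiens) for antiproliferative activity, read by MTT assay, with a stated time of 48 h; on this read-out higher numbers stand for weaker inhibition and lower numbers for stronger inhibition:

Compound 1 `COc1cc(-c2nn(-c3ccc(NC(=O)c4cc(Cl)cc(Cl)c4)cc3)cc2-c2ccncc2)ccc1Cl` – compound 1 gives only a limit of the assay, > 20000 nM.
Compound 2 `COc1cc(-c2nn(-c3ccc(NC(=O)c4cc(C(F)(F)F)cc(C(F)(F)F)c4)cc3)cc2-c2ccncc2)ccc1Cl` – compound 2 likewise gives only a limit of the assay, > 20000 nM.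
Compound 3 `O=C(Nc1ccc(-n2cc(-c3ccncc3)c(-c3ccc(Cl)c(O)c3)n2)cc1)c1cc(Cl)cc(Cl)c1` – compound 3 gives 6800 nM.

Compound 1 and compound 3 differ in one place, (hydrogen in place of methyl on an oxygen on an aromatic ring), and this change brings an at least 2.9-fold lower number from compound 1 to compound 3 (0.46 log units; beyond the scatter). Because the value of compound 1 sits at the limit of > 20000 nM in this assay, at which 2 of the 3 values shown sit, the true size of that step is only known as a lower bound. The difference between the cores of compound 1 and compound 2 is not broken down here; both sit at the limit of this assay.

Compound 4 `O=C(Nc1ccc(-n2cc(-c3ccncc3)c(-c3ccc(Cl)c(O)c3)n2)cc1)c1cc(C(F)(F)F)cc(C(F)(F)F)c1` has not been measured in this assay. It stands to compound 2 exactly as compound 3 stands to compound 1: the same change, (hydrogen in place of methyl on an oxygen on an aromatic ring), at the same place. On the strength of the step from compound 1 to compound 3 alone, compound 4 is expected to show an at least 2.5-fold lower number from compound 2 to compound 4 (0.39 log units; beyond the scatter), with the size resting on a single precedent whose start point is itself a limit. Compound 4 is therefore estimated at 8000 nM, within a range of 3000 nM to 20000 nM.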

Compound 4, half-maximal inhibitory concentration: > 20000 nM
Compound 4: a limit, no number; the forecaster's own chance of this, stated with the estimate: 35%; middle value at least 2.5-fold (0.39 log units) away from the limit.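

In this assay compound 4 gives only a limit of the assay, > 20000 nM. Compound 2 gives the same limit, so no step from compound 2 to compound 4 can be read: the limit of > 20000 nM in this assay, at which 3 of the 4 values shown sit.

The compounds shown leave open whether methoxy to hydroxy lowers the number at all in the series of compound 2 and compound 4, as it does from compound 1 to compound 3.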